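Dropping the ring fluorine from compound 1

This account rests on a few compounds, and the source may have more. Where it says the series, first, only, none or still open, it means among the compounds named here.

Compound 1 `C=C(Br)C(=O)Nc1cccc(/C=C2\SC(=O)N(Cc3cccc(F)c3)C2=O)c1`: 690 nM
Compound 2 `Nc1cccc(/C=C2\SC(=O)N(Cc3cccc(F)c3)C2=O)c1`: > 250000 nM, a limit of the assay

Among the compounds with values here, in a functional assay on FM3A cells (Mus musculus) for cytotoxicity, read by cell counting, with a stated time of 2 days (a higher number here means a weaker inhibitor, a lower number a stronger inhibitor), compound 1 gives 690 nM, the only number among the values shown. For compound 2 the result stands at the limit of > 250000 nM in this assay, at which 1 of the 2 values shown sits, which is a limit and not a number. The step of an at least 360-fold higher number from compound 1 to compound 2 (2.55 log units; beyond the scatter) is large. Compound 3 `C=C(Br)C(=O)Nc1cccc(/C=C2\SC(=O)N(Cc3ccccc3)C2=O)c1` differs from compound 1 by hydrogen in place of fluoro on an aromatic carbon. No measured step touches that position; the single step shown concerns the amide nitrogen, which compound 3 keeps unchanged. The expectation is therefore no step beyond the scatter, a 1.2-fold higher number from compound 1 to compound 3 (0.06 log units; within the scatter). Compound 3 is estimated at 800 nM, between 300 nM and 2500 nM.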

Compound 3, half-maximal inhibitory concentration: 810 nM
The estimate for compound 3 lay 1.0-fold (0.01 log units) below the measured number; the measured number falls inside the stated range.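

In this assay, the step at the ring position is a 1.2-fold higher number from compound 1 to compound 3 (0.07 log units; within the scatter). Within the data shown here, this is the first look at the 3-fluorobenzyl group, which the earlier compounds left unchanged: with benzyl in its place, the cytotoxicity of the series stands, so the fluoro group is not required for it. Nothing measured here bears on why this is so. As far as these compounds go, whether a chloro, methoxy or amine group on that aromatic carbon would read the same stays open, as does the effect of a longer chain in place of benzyl.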